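A few compounds are considered here, and "the series" means these few. Any claim that something is new, unique, unknown or untested is made for them only; others in the source may bear on it.

Measured so far in an ADME assay on a cell-free system (plasma, Homo sapiens) for metabolic stability, with Plasma (Rattus norvegicus) as the target, read by HPLC, at pH 7.4; on this read-out higher numbers stand for a longer-lived compound and lower numbers for a shorter-lived compound:
Compound 1 `CCC(=O)O[C@@H]1CO[C@H]2[C@@H]1OC[C@@H]2OC(=O)c1ccccc1OC(C)=O` gives 0.011 h.
Compound 2 `CC(=O)Oc1ccccc1C(=O)O[C@H]1CO[C@H]2[C@@H]1OC[C@H]2OC(=O)C1CC1` gives 0.015 h.
Compound 3 `CC(=O)Oc1ccccc1C(=O)O[C@H]1CO[C@H]2[C@@H]1OC[C@H]2OC(=O)c1cccc(C)c1` gives 0.0203 h.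

Compound 1 holds the lowest of the three numbers, yet no gap around it is telling: the step to its nearest neighbour is a 1.4-fold higher number from compound 1 to compound 2 (0.13 log units; within the scatter), and to its furthest is a 1.8-fold higher number from compound 1 to compound 3 (0.27 log units; within the scatter). Between the other two the step is a 1.4-fold higher number from compound 2 to compound 3 (0.13 log units; within the scatter). All three half-lives therefore sit within the scatter of one another.

The next compound is compound 4 `CC(=O)Oc1ccccc1C(=O)O[C@H]1CO[C@H]2[C@@H]1OC[C@H]2OC(=O)c1ccc(-c2ccccc2)cc1`. Its difference from compound 1: 4-phenylphenyl in place of ethyl on a carbonyl carbon. Within the data shown here, two measured steps bear on this change. Both exchange the same ethyl on the same carbonyl carbon: a 1.4-fold higher number from compound 1 to compound 2 (0.13 log units; within the scatter) and a 1.8-fold higher number from compound 1 to compound 3 (0.27 log units; within the scatter). Neither step left the scatter, and the 3-methylphenyl step in compound 3 is the closer comparison for a 4-phenylphenyl entering at that position. On this basis compound 4 is expected to show, at most, a lean upward that stays within the scatter, not a clear change.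

Compound 4 is therefore estimated at 0.022 h, with a range from 0.01 h to 0.05 h. That estimate means an expected step of a 2.0-fold higher number from compound 1 to compound 4 (0.30 log units; within the scatter).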

Compound 4, half-life: > 0.333 h
Compound 4 ended at the assay's limit; the forecaster's own chance of this, stated with the estimate: 5%; middle value at least 15-fold (1.18 log units) from the limit.
By their numbers in this assay, from the lowest: compounds 1, 2 and 3 (each within the scatter of the next). At a limit, above all of these: compound 4.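

In this assay compound 4 gives > 0.333 h, which is a limit of the assay and not a number: the limit of > 0.333 h in this assay, at which 1 of the 4 values shown sits. Ethyl, cyclopropyl and 3-methylphenyl on this carbonyl carbon, whose other neighbours are oxygen next to a carbonyl group, had stayed within the scatter of one another, whereas 4-phenylphenyl gives an at least 30-fold higher number from compound 1 to compound 4 (1.48 log units; beyond the scatter), an at least 22-fold higher number from compound 2 to compound 4 (1.34 log units; beyond the scatter) and an at least 16-fold higher number from compound 3 to compound 4 (1.21 log units; beyond the scatter). The position is therefore not indifferent to the group it carries, and a single aromatic ring does not mark the difference: compound 3 carries 3-methylphenyl and stays within the scatter of compound 1 and compound 2, while the large step appears only with 4-phenylphenyl.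

Going by these compounds, the full size of these steps stays unknown, and with one compound showing the effect, nothing separates the second phenyl ring from the group's length or from its attachment at the 4-position. A plain phenyl, a 4-methylphenyl, a 3-phenylphenyl or a longer alkyl chain on the same carbonyl carbon would be needed to tell where between 3-methylphenyl and 4-phenylphenyl the half-life begins to rise.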